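The source may hold more compounds than are shown below. What is called first, only, known or untested is meant among the compounds shown, and "the series" means these compounds.

Compound 1 `CCc1cccc2c1nc(-c1c(F)cccc1F)n2Cc1c(F)cccc1F` is tested in a toxicity assay on CCRF-CEM cells (Homo sapiens) for cytotoxicity (a lower number here means that less compound is tolerated, a higher number that more compound is tolerated), where compound 1 gives 26.1 uM. Compound 3 `CC(=O)Nc1cccc2c1nc(-c1c(F)cccc1F)n2Cc1c(F)cccc1F` gives 39.3 uM in this assay, and the step of a 1.5-fold higher number from compound 1 to compound 3 (0.18 log units; within the scatter) keeps these two within the usual scatter of each other. Compound 2 `Oc1cccc2c1nc(-c1c(F)cccc1F)n2Cc1c(F)cccc1F` reaches only a limit of this assay, > 100 uM; (the limit of > 100 uM in this assay, at which 1 of the 3 values shown sits). Compound 4 `CN(C)c1cccc2c1nc(-c1c(F)cccc1F)n2Cc1c(F)cccc1F` is the next one to be measured; it differs from compound 1 by dimethylamino in place of ethyl on an aromatic carbon. Two measured steps from compound 1 bear on this change: an at least 3.8-fold higher number from compound 1 to compound 2 (0.58 log units; beyond the scatter), which was at least modest, and a 1.5-fold higher number from compound 1 to compound 3 (0.18 log units; within the scatter), which stayed within the scatter. A small rise in the tolerated concentration is therefore expected, a 1.5-fold higher number from compound 1 to compound 4 (0.19 log units; within the scatter). Compound 4 is thus estimated at 40 uM, with a range from 15 uM to 110 uM.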

Compound 4, half-maximal toxic concentration: > 100 uM
Compound 4 was reported as a limit; the forecaster's own chance of this, stated with the estimate: 20%; middle value at least 2.5-fold (0.39 log units) from the limit.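

In this assay, dimethylamino on this aromatic carbon gives a clear shift from the ethyl compound, an at least 3.8-fold higher number from compound 1 to compound 4 (0.58 log units; beyond the scatter), so hydroxy is no longer the only replacement shown to do so. A nitrogen at this position does not settle the outcome on its own, as acetamido in compound 3 stays within the scatter of ethyl while dimethylamino separates from it: an at least 2.5-fold higher number from compound 3 to compound 4 (0.40 log units; beyond the scatter). Compound 2 and compound 4 cannot be ranked against each other, as both values are limits: the limit of > 100 uM in this assay, at which 2 of the 4 values shown sit.

Going by these compounds, the actual numbers for compound 2 and compound 4 remain open. So does whether a primary amine or a carboxylic acid here would track dimethylamino or acetamido.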